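Swapping the amide substituent: from tolyl toward cyclohexyl

The source may hold more compounds than are shown below. What is called first, only, known or untested is meant among the compounds shown, and "the series" means these compounds.

Measured so far:
- compound 1, `COc1cc(-c2cc(C(=O)O)c3ccccc3n2)ccc1OCC(=O)Nc1ccccc1C`, 0.8
- compound 2, `COc1cc(-c2cc(C(=O)O)c3ccccc3n2)ccc1OCC(=O)Nc1ccc(Cl)cc1`, 1.5
- compound 3, `CCCCCCNC(=O)COc1ccc(-c2cc(C(=O)O)c3ccccc3n2)cc1OC`, 1

These three compounds share one core and differ only in the group on the amide-type nitrogen. In a physicochemical assay for lipophilicity, using the shake flask method, in phosphate buffer, measured as octanol-water partition, at pH 7.4 (on this read-out lower numbers stand for lower lipophilicity and higher numbers for higher lipophilicity), compound 1 gives the lowest of the three numbers. Its nearest neighbour is compound 3: a number 0.20 log units higher from compound 1 to compound 3 (within the scatter). The furthest is compound 2: a number 0.70 log units higher from compound 1 to compound 2 (beyond the scatter).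

Compound 4, `COc1cc(-c2cc(C(=O)O)c3ccccc3n2)ccc1OCC(=O)NC1CCCCC1`, has not been measured. It departs from compound 1 in one place: cyclohexyl in place of 2-methylphenyl on an amide-type nitrogen.

For the measured compounds named here, two measured steps bear on this change, since both also replace the 2-methylphenyl group on the amide-type nitrogen. Replacing it with hexyl gave a number 0.20 log units higher from compound 1 to compound 3 (within the scatter), while replacing it with 4-chlorophenyl gave a number 0.70 log units higher from compound 1 to compound 2 (beyond the scatter). Cyclohexyl is a saturated ring of six carbon atoms, which sits closer to hexyl than to 4-chlorophenyl among the measured choices, so a small shift, if any, is expected in this assay: a number 0.20 log units higher from compound 1 to compound 4 (within the scatter). Compound 4 is therefore estimated at 1, between 0.5 and 1.5.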

Compound 4, distribution coefficient: 0.8
The estimate for compound 4 lay 0.20 log units above the measured number; the range from low to high includes it.
By their numbers in this assay, from the lowest: compounds 1, 4 and 3 (each within the scatter of the next); then compound 2.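

In this assay, exchanging the aromatic ring of 2-methylphenyl for the non-aromatic ring of cyclohexyl gives no change at the digits printed from compound 1 to compound 4 (within the scatter). Closing an open chain into a ring also separates nothing, with hexyl and cyclohexyl giving a number 0.20 log units lower from compound 3 to compound 4 (within the scatter), so compounds 1, 3 and 4 form one group within the scatter, and only the 4-chlorophenyl group stands clear of them, as in a number 0.70 log units lower from compound 2 to compound 4 (beyond the scatter). Nothing available explains why this one group stands apart.

The compounds shown leave open whether the chlorine or its place on the ring matters, which a plain phenyl group or a 2-chlorophenyl group on this nitrogen could help to separate. Going by these compounds, how a group carrying an amine or a carboxylic acid would read at this position also stays open.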